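The source may hold more compounds than are shown below. What is called first, only, known or untested is meant among the compounds shown, and "the series" means these compounds.

Compound 1 `O=S(=O)(Nc1ccc(-c2nc3ccccc3o2)cc1)c1cccc(O)c1` is the anchor of this step. In an ADME assay on HEK293 cells (Homo sapiens) for cytotoxicity, read by resazurin assay, with a stated time of 48 h (on this read-out higher numbers stand for lower toxicity in this test and lower numbers for higher toxicity in this test), compound 1 gives only a limit, > 100000 nM, so its standing among the measured numbers is known as a limit alone, (the limit of > 100000 nM in this assay, at which 1 of the 3 values shown sits). Compound 2 `O=S(=O)(Nc1ccc2oc(-c3ccccc3)nc2c1)c1cccs1` gives 97000 nM in this assay, and compound 3 `COc1ccc(S(=O)(=O)Nc2ccc3oc(-c4ccccc4)nc3c2)cc1` gives 91000 nM. For the measured compounds named here, the one measured step, a 1.1-fold lower number from compound 2 to compound 3 (0.03 log units; within the scatter), changes the aryl group on the sulfonyl sulfur and leaves the read-out where it was. Compound 4 `CCc1ccc(S(=O)(=O)Nc2ccc(-c3nc4ccccc4o3)cc2)cc1` differs from compound 1 by 4-ethylphenyl in place of 3-hydroxyphenyl on a sulfonyl sulfur. No measured step exchanges these same groups, so the only bearing is a general one: among these three compounds, changing the aryl on the sulfonyl sulfur has not moved the read-out beyond the scatter, as a 1.1-fold lower number from compound 2 to compound 3 (0.03 log units; within the scatter) shows, and every measured value sits near the top of the range. The step is therefore expected to remain within the scatter, an at least 1.1-fold lower number from compound 1 to compound 4 (0.04 log units; that floor lies within the scatter). Compound 4 is estimated at 90000 nM, with a range from 45000 nM to 100000 nM.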

Compound 4, half-maximal cytotoxic concentration: 82000 nM
Estimate against measurement, compound 4: 1.1-fold (0.04 log units) above; the range from low to high includes it.
By their numbers in this assay, from the lowest: compounds 4, 3 and 2 (each within the scatter of the next). At a limit, above all of these: compound 1.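

The exchange of 3-hydroxyphenyl for 4-ethylphenyl on a sulfonyl sulfur gives an at least 1.2-fold lower number from compound 1 to compound 4 (0.08 log units; that floor lies within the scatter) in this assay. Compound 1 stands only at a limit, and the full size of this step cannot be read: the limit of > 100000 nM in this assay, at which 1 of the 4 values shown sits.

For the compounds shown here, compound 4 provides the first number rather than a limit on the core of compound 1, and a group with no hydrogen-bond donor or acceptor at this place brings no step printed as beyond the scatter.

Still open, going by these compounds, is whether an amine, a carboxylic acid or a longer chain in place of the ethyl group would bring a step beyond the scatter in this assay. Also open, on these data alone, is whether 3-hydroxyphenyl and 4-ethylphenyl give the same picture on the core of compound 2.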